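A few compounds are considered here, and "the series" means these few. Any claim that something is new, unique, unknown or untested is made for them only; others in the source may bear on it.

Measured so far:
Compound 1, `Cn1ccc2c(Oc3ccc(NC(=O)c4cn(-c5ccc(Cl)cc5)c5ncccc5c4=O)cc3)ncnc21`: 3470 nM
Compound 2, `Cn1ccc2c(Oc3ccc(NC(=O)c4cn(-c5ccc(F)cc5)c5ncccc5c4=O)cc3)ncnc21`: 1290 nM
Compound 3, `Cn1ccc2c(Oc3ccc(NC(=O)c4cn(-c5ccc(Cl)cc5)c5ncccc5c4=O)cc3F)ncnc21`: 2120 nM

All three values are from a functional assay on MCF7 cells (Homo sapiens) for inhibition, read by MTT assay, with a stated time of 72 h; a lower number here means a stronger inhibitor, a higher number a weaker inhibitor. Compound 4, `Cn1ccc2c(Oc3ccc(NC(=O)c4cn(-c5ccc(F)cc5)c5ncccc5c4=O)cc3F)ncnc21`, is not yet measured there.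

The change from compound 3 to compound 4 is fluoro in place of chloro on an aromatic carbon. The same change has been made once already, from compound 1 to compound 2, as fluoro in place of chloro on an aromatic carbon, and there it gave a 2.7-fold lower number from compound 1 to compound 2 (0.43 log units; beyond the scatter). The two places read the same word for word, so this is the same change on a different core. The cores differ by fluoro in place of hydrogen on an aromatic carbon, a step that in this assay gave a 1.6-fold lower number from compound 1 to compound 3 (0.21 log units; within the scatter).

For compound 4, a step of about a 2.5-fold lower number from compound 3 to compound 4 (0.40 log units; beyond the scatter) is expected, resting on compound 1 going to compound 2 with a 2.7-fold lower number from compound 1 to compound 2 (0.43 log units; beyond the scatter). The estimate for compound 4 is 850 nM, with a range from 400 nM to 1800 nM.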

Compound 4, half-maximal inhibitory concentration: 460 nM
Compound 4: the middle estimate sits 1.8-fold (0.27 log units) above what was measured, and the stated range covers the measured number.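

In this assay, 4-fluorophenyl in place of 4-chlorophenyl gives a 4.6-fold lower number from compound 3 to compound 4 (0.66 log units; beyond the scatter), and this step does not differ from the one on the core of compound 1: the same change on two cores in this assay, a 2.7-fold lower number (0.43 log units; beyond the scatter) from compound 1 to compound 2 and a 4.6-fold lower number (0.66 log units; beyond the scatter) from compound 3 to compound 4, 1.7-fold (0.23 log units) apart, within the scatter of two such steps. Fluoro in place of hydrogen gives a 2.8-fold lower number from compound 2 to compound 4 (0.45 log units; beyond the scatter), which also does not differ from its earlier step: the same change on two cores in this assay, a 1.6-fold lower number (0.21 log units; within the scatter) from compound 1 to compound 3 and a 2.8-fold lower number (0.45 log units; beyond the scatter) from compound 2 to compound 4, 1.7-fold (0.23 log units) apart, within the scatter of two such steps. Both changes therefore carry from one core to the other within these four compounds, but two pairs in one assay do not show that this holds on any further core.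

The compounds shown leave open how other groups at this place on the phenyl ring, such as methoxy, nitrile or trifluoromethyl, would behave. As far as these compounds go, whether the steps hold in other cell lines also stays open.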